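The source may report more compounds than this note shows. Statements on the series, on what has been measured and on what is new or still open speak of the compounds shown alone.

Measured compounds:
- compound 1 `O=C(NS(=O)(=O)c1ccccc1)c1cccnc1`: 11500 nM
- compound 2 `Cc1ccc(S(=O)(=O)NC(=O)c2cccnc2)cc1`: 15500 nM

Within the data shown here, in a functional assay on MCF7 cells (Homo sapiens) for antiproliferative activity, read by colorimetric assay and MTT assay, with a stated time of 48 h (on this read-out higher numbers stand for weaker inhibition and lower numbers for stronger inhibition), compound 1 stands level with compound 2, its only measured neighbour, and the step of a 1.3-fold higher number from compound 1 to compound 2 (0.13 log units; within the scatter) is the only one available. That step, methyl in place of hydrogen on an aromatic carbon, leaves pyridin-3-yl untouched, so it offers only weak guidance. Compound 3 `O=C(NS(=O)(=O)c1ccccc1)c1ccccn1` has the same atoms as compound 1, joined differently: pyridin-2-yl in place of pyridin-3-yl on a carbonyl carbon. Among the measured compounds shown here, no measured step tests pyridin-2-yl in place of pyridin-3-yl on a carbonyl carbon, so no change beyond the scatter is expected, in either direction. The expected step is a 1.0-fold higher number from compound 1 to compound 3 (0.02 log units; within the scatter). For compound 3 the estimated value is 12000 nM, with an expected range of 4500 nM to 32000 nM.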

Compound 3, half-maximal inhibitory concentration: 10600 nM
Beside the measured number, compound 3's estimate is 1.1-fold (0.05 log units) above it, and the stated range covers the measured number.
By their numbers in this assay, from the lowest: compounds 3, 1 and 2 (each within the scatter of the next).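

Pyridin-2-yl in place of pyridin-3-yl on a carbonyl carbon, the part that the earlier step left untouched, gives in this assay a 1.1-fold lower number from compound 1 to compound 3 (0.04 log units; within the scatter). At this place, on a carbonyl carbon whose other neighbour is an amide-type nitrogen, the two groups therefore cannot be told apart by this read-out. Nothing available bears on why this is so.

On these data alone, what an amine or a carboxylic acid on pyridin-2-yl would do remains open. So does whether the same change would give a similar result in the presence of the methyl carried by compound 2.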